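A few compounds are considered here, and "the series" means these few. Any claim that something is new, unique, unknown or untested is made for them only; others in the source may bear on it.

Four compounds share one core and differ in the aromatic group attached to a side chain and in the length of that chain. Compound 1 `N=C(NCCCc1c[nH]cn1)NCCC(c1ccccc1)c1ccccn1` and compound 3 `N=C(NCCCc1c[nH]cn1)NCCC(c1ccc(Cl)c(Cl)c1)c1ccccn1` make up one pair, compound 2 `N=C(NCCCc1c[nH]cn1)NCCCC(c1ccccc1)c1ccccn1` and compound 4 `N=C(NCCCc1c[nH]cn1)NCCCC(c1ccc(Cl)c(Cl)c1)c1ccccn1` the other. In a functional assay on cardiac atrium for agonist activity at histamine H2 receptor (Cavia porcellus) (on this read-out higher numbers stand for higher potency (the scale is a negative logarithm) and lower numbers for lower potency), compound 1 gives 7.39, while compound 3 gives 8.19. The change that separates these two is 3,4-dichlorophenyl in place of phenyl on a saturated chain carbon bound to an aromatic carbon and a saturated chain carbon and it produced the step of a number 0.80 log units higher from compound 1 to compound 3 (beyond the scatter). Compound 2 gives 6.61 in this assay, the lowest of the three measured numbers. How the core of compound 2 differs from that of compound 1 is not broken down here.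

Compound 4 has not yet been measured. Its difference from compound 2 is 3,4-dichlorophenyl in place of phenyl on a saturated chain carbon bound to an aromatic carbon and a saturated chain carbon, which is the same change, at the same kind of position, as the one seen between the measured pair. Because that change earlier gave the step of a number 0.80 log units higher from compound 1 to compound 3 (beyond the scatter), a step of similar size is expected here, namely a number 0.74 log units higher from compound 2 to compound 4 (beyond the scatter). This expectation rests on a single measured pair, so some spread around it is allowed, and nothing in the data shows whether the longer chain alters the size of the step. Compound 4 is therefore expected to give about 7.35 in this assay, most likely between 6.85 and 7.85.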

Compound 4, negative logarithm of the half-maximal effective concentration: 6.67
Estimate against measurement, compound 4: 0.68 log units above, and the stated range ends above it.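

In this assay, putting 3,4-dichlorophenyl in place of phenyl on the core of compound 2 gives a number 0.06 log units higher from compound 2 to compound 4 (within the scatter), so on this core the swap brings no gain that can be told apart from ordinary repeat-to-repeat variation. The same swap therefore does not carry the same effect from one core to the other, and a step measured on one core is a poor guide to the other here: the same change on two cores in this assay, a number 0.80 log units higher (beyond the scatter) from compound 1 to compound 3 and a number 0.06 log units higher (within the scatter) from compound 2 to compound 4, 0.74 log units apart, beyond the scatter of two such steps What this does not show is why the two steps differ, since the longer chain in compound 2 and compound 4 is only the visible difference between the cores and nothing here tests it as the cause, and two pairs cannot say how the swap would behave on any further core.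

As far as these compounds go, it remains open whether a single chlorine or a methoxy group in place of 3,4-dichlorophenyl would follow the pattern of compound 3 or that of compound 4 on these two cores. The compounds shown also leave open how the swap behaves with a shorter chain than in compound 1 or a longer chain than in compound 2, which would show whether the step shrinks gradually or abruptly.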